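Swapping acetyl for methyl on compound 1's pyrazole nitrogen

A few compounds are considered here, and "the series" means these few. Any claim that something is new, unique, unknown or untested is made for them only; others in the source may bear on it.

Measured compounds:
- compound 1, `CNC(=O)N1CCCc2ccc(NC(=O)c3cccc(-c4ccn(C(C)=O)n4)c3)cc21`: 27.6%
- compound 2, `CNC(=O)N1CCCc2ccc(NC(=O)c3ccc(-c4cnn(C(C)=O)c4)cc3)cc21`: 23.9%
- compound 3, `CNC(=O)N1CCCc2ccc(NC(=O)c3ccccc3-c3ccccc3)cc21`: 10.7%

Three compounds sharing one core were tested in a functional assay on MV4-11 cells (Homo sapiens) for antiproliferative activity, with a stated time of 6 days, tested at 1.56 uM; on this read-out higher numbers stand for a stronger effect at the one concentration tested and lower numbers for a weaker effect. Compound 1 gives the highest of the three numbers, and compound 2 sits within the usual scatter of it, so no order between those two can be read. Compound 3, which carries a plain phenyl in place of the acetylated pyrazole, lies clearly lower than compound 1, beyond the scatter.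

Compound 4, `CNC(=O)N1CCCc2ccc(NC(=O)c3cccc(-c4ccn(C)n4)c3)cc21`, has not been measured. It differs from compound 1 in one place: methyl in place of acetyl on an aromatic nitrogen. Among the measured compounds shown here, no pair among the measured compounds shows this kind of change, so there is no measured step to lean on. The expected step of a number 5.6 percentage points lower from compound 1 to compound 4 (within the scatter) is a modest one, likely within the scatter or slightly downward, since the acetylated pyrazoles in compound 1 and compound 2 both give the higher numbers. Compound 4 is therefore estimated at 22%, with a range from 5% to 42%.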

Compound 4, a percentage reported as inhibition, at one concentration (the size of the read-out at that concentration, not a potency): 70.5%
Compound 4: middle estimate off by 48.5 percentage points, on the low side; measured number above the stated range.
By their numbers in this assay, from the lowest: compound 3; then compounds 2 and 1 (each within the scatter of the next); then compound 4.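

In this assay methyl in place of acetyl on the aromatic nitrogen gives a number 42.9 percentage points higher from compound 1 to compound 4 (beyond the scatter) and so counts as a large step. Among the compounds shown here, this shows that the group on this pyrazole nitrogen can strongly shift the read-out, which the earlier compounds could not show, as no two of them differ at this nitrogen alone and both of the pyrazoles among them carry acetyl. The change removes a carbonyl and leaves the pyrazole in place, but nothing available explains the size of the step.

On these data alone, it remains open whether methyl itself matters or whether losing acetyl is enough, and a plain hydrogen, an ethyl group or a longer chain on that nitrogen would help to separate the two. As far as these compounds go, it is also open whether the same swap would give a similar step on the pyrazole of compound 2.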